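Fluorine at a new position on the outer phenyl ring

A few compounds are considered here, and "the series" means these few. Any claim that something is new, unique, unknown or untested is made for them only; others in the source may bear on it.

Measured compounds in a functional assay on HCT-116 cells (Homo sapiens) for cytotoxicity, with a stated time of 48 h; on this read-out higher numbers stand for weaker inhibition and lower numbers for stronger inhibition:
- compound 1, `O=[N+]([O-])c1ccc(CN2CCC(n3cc(CC(OCc4cc(-c5cccc(Br)c5)no4)c4ccc(Br)cc4)nn3)CC2)cc1`: > 25000 nM, which is a limit of the assay and not a number
- compound 2, `O=[N+]([O-])c1ccc(CN2CCC(n3cc(CC(OCc4cc(-c5cccc(F)c5)no4)c4ccc(Br)cc4)nn3)CC2)cc1`: 6000 nM
- compound 3, `O=[N+]([O-])c1ccc(CN2CCC(n3cc(CC(OCc4cc(-c5ccccc5Br)no4)c4ccc(Br)cc4)nn3)CC2)cc1`: > 25000 nM, which is a limit of the assay and not a number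

Compound 1 therefore stands at the upper boundary of what this assay can report, and no number is known for it; only compound 2 gives a number in this group.

The new compound 4, `O=[N+]([O-])c1ccc(CN2CCC(n3cc(CC(OCc4cc(-c5ccccc5F)no4)c4ccc(Br)cc4)nn3)CC2)cc1`, differs from compound 1 in one place: 2-fluorophenyl in place of 3-bromophenyl on an aromatic carbon.

For the measured compounds named here, two measured steps bear on this. Swapping bromo for fluoro at the same position gave an at least 4.1-fold lower number from compound 1 to compound 2 (0.61 log units; beyond the scatter), so fluorine on this ring is linked with stronger inhibition. Moving the bromine to the 2-position, however, gave an at least 4.1-fold higher number from compound 2 to compound 3 (0.61 log units; beyond the scatter), and the step that the two limits leave unreadable from compound 1 to compound 3 cannot be read, since both compounds sit at the limit (the limit of > 25000 nM in this assay, at which 2 of the 3 values shown sit).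

Going by the values given here, compound 4 carries both changes at once: the favourable halogen, but at the position where the only measured example was inactive. A step of roughly an at least 1.6-fold lower number from compound 1 to compound 4 (0.22 log units; that floor lies within the scatter) is expected, possibly no readable change at all. Compound 4 is therefore estimated at 15000 nM, within 5000 nM to 40000 nM.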

Compound 4, half-maximal inhibitory concentration: 9000 nM
For compound 4 the middle estimate is 1.7-fold (0.22 log units) above the measured one; measured number inside the range.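

In this assay, a halogen on the 2-position of the phenyl ring does not by itself leave a compound at the limit, since replacing bromo with fluoro there gives an at least 2.7-fold lower number from compound 3 to compound 4 (0.44 log units; beyond the scatter). The combined change also gives an at least 2.7-fold lower number from compound 1 to compound 4 (0.44 log units; beyond the scatter), while the two fluoro compounds cannot be told apart, with a 1.5-fold higher number from compound 2 to compound 4 (0.18 log units; within the scatter), so among the fluoro compounds shown the choice between 2-fluorophenyl and 3-fluorophenyl makes no readable difference. The link between fluoro in place of bromo and stronger inhibition, earlier seen in a single pair, now holds in both pairs that allow this comparison: the same change on two cores in this assay, an at least 4.1-fold lower number (0.61 log units; beyond the scatter) from compound 1 to compound 2 and an at least 2.7-fold lower number (0.44 log units; beyond the scatter) from compound 3 to compound 4; the limit leaves it open whether they differ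

As far as these compounds go, compound 1 and compound 3 both stand at a limit, so the true size of the gain from fluoro stays unknown, and the steps between these two compounds cannot be read: the limit of > 25000 nM in this assay, at which 2 of the 4 values shown sit. It also stays open whether a chloro group, a methoxy group or an amine in place of the halogen on this phenyl ring would give a lower number than fluoro does.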